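A few compounds are considered here, and "the series" means these few. Any claim that something is new, unique, unknown or untested is made for them only; others in the source may bear on it.

In a functional assay on A2780 cells (Homo sapiens) for antiproliferative activity, read by CellTiter-Glo, with a stated time of 72 h (on this read-out higher numbers stand for weaker inhibition and lower numbers for stronger inhibition), compound 1 (`C[C@@H](c1ccc(NC(=O)N2CC(c3cccnc3)C2)cc1)N1Cc2ccccc2C1=O`) gives 1.5 nM while compound 2 (`C[C@@H](c1ccc(NC(=O)N2CC(c3ccc(N)nc3)C2)cc1)N1Cc2ccccc2C1=O`) gives 5.9 nM and so holds the higher of the two numbers, meaning the weaker inhibition of the pair. Compound 3 (`C[C@@H](c1ccc(NC(=O)N2CC(c3cncc(N)c3)C2)cc1)N1Cc2ccccc2C1=O`) has the same atoms as compound 2 joined differently: 5-aminopyridin-3-yl in place of 6-aminopyridin-3-yl on a saturated ring carbon. Among the compounds with values here, one measured step bears on this change, amino in place of hydrogen on an aromatic carbon, which brought a 3.9-fold higher number from compound 1 to compound 2 (0.59 log units; beyond the scatter) and counts as modest. Within the data shown here, no measured step moves an amino group, so this guide is indirect. Compound 3 keeps the amino group, so in this assay a shift larger than that modest one is not expected, and most likely none beyond the scatter. The expected change is a 1.3-fold lower number from compound 2 to compound 3 (0.12 log units; within the scatter) and lies within the scatter. For compound 3 the estimated value is 4.5 nM with an expected range from 1.5 nM to 15 nM in this measurement.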

Compound 3, half-maximal inhibitory concentration: 45 nM
For compound 3 the middle estimate is 10-fold (1.00 log units) below the measured one, outside the stated range (above it).
By their numbers in this assay, from the lowest: compound 1; then compound 2; then compound 3.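

The position of the amino group on the aromatic ring matters, not just its presence. In this assay the swap of 6-aminopyridin-3-yl for 5-aminopyridin-3-yl, with the same atoms joined differently, gives a 7.6-fold higher number from compound 2 to compound 3 (0.88 log units; beyond the scatter) and so weakens inhibition. Against the unsubstituted compound 1, the amino group costs far more in this new placement, at a 30-fold higher number from compound 1 to compound 3 (1.48 log units; beyond the scatter) compared with a 3.9-fold higher number from compound 1 to compound 2 (0.59 log units; beyond the scatter) for the earlier placement. Nothing available explains why the placement has this effect.

The compounds shown leave open whether this sensitivity belongs to the amino group or would appear with any group in that place. A methyl or hydroxyl group in the place of the amino group of compound 3 would help to separate the two.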